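The compounds below may be only part of what the source reports. "The series", "measured", "known", "first", "only" and "open" are said of these compounds alone.

Measured compounds:
- Compound 1, `CCN(CC)CCCNC(=O)c1ccc(C(CC)(CC)c2ccc(OCC(=O)C(C)(C)C)c(C)c2)n1CC`: 22 nM
- Compound 2, `CCn1c(C(=O)N(C)CCC#N)ccc1C(CC)(CC)c1ccc(OCC(=O)C(C)(C)C)c(C)c1`: 9800 nM
- Compound 3, `CCN(CC)CCCNC(=O)c1ccc(C(CC)(CC)c2ccc(OCC(O)C(C)(C)C)c(C)c2)n1CC`: 66 nM

These three compounds were tested in an assay on HL-60 cells for agonist activity at vitamin D3 receptor (Homo sapiens), read by microscopy, with a stated time of 96 h; a lower number here means that less compound is needed, a higher number that more compound is needed for the effect. Compound 3 stands second highest of the three numbers: it sits a 3.0-fold higher number from compound 1 to compound 3 (0.48 log units; beyond the scatter), and compound 3 gives 66 nM while compound 2 gives 9800 nM.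

Compound 4, `C#CCCOC(=O)c1ccc(C(CC)(CC)c2ccc(OCC(O)C(C)(C)C)c(C)c2)n1CC`, has not yet been measured. It differs from compound 3 in one place: (but-3-yn-1-yl)oxy in place of (3-(diethylamino)propyl)amino on a carbonyl carbon.

Among the compounds with values here, the one measured step that bears on this change is a 450-fold higher number from compound 1 to compound 2 (2.65 log units; beyond the scatter), where the same (3-(diethylamino)propyl)amino group on the carbonyl carbon was also removed. That step was large, and the present change likewise takes away the (3-(diethylamino)propyl)amino group while bringing in a group without a hydrogen-bond donor. A large step upward in this assay is therefore expected, a 110-fold higher number from compound 3 to compound 4 (2.03 log units; beyond the scatter). Compound 4 is estimated at 7000 nM, within a range of 1000 nM to 40000 nM.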

Compound 4, half-maximal effective concentration: 1030 nM
Beside the measured number, compound 4's estimate is 6.8-fold (0.83 log units) above it, and the stated range covers the measured number.
By their numbers in this assay, from the lowest: compound 1; then compound 3; then compound 4; then compound 2.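

In this assay the change from (3-(diethylamino)propyl)amino to (but-3-yn-1-yl)oxy on a carbonyl carbon gives a 16-fold higher number from compound 3 to compound 4 (1.19 log units; beyond the scatter), which shows that losing this group also costs activity when the 1-hydroxy-2,2-dimethylpropyl group is present, not only with the (tert-butyl)carbonyl group. The earlier step, a 450-fold higher number from compound 1 to compound 2 (2.65 log units; beyond the scatter), is the larger of the two, but the pairs differ in both the entering group and the starting compound, so the difference in size cannot be assigned to either one. Nothing given here explains the loss in either pair.

The compounds shown leave open whether the loss follows from removing the diethylamino nitrogen or the amide hydrogen. A (but-3-yn-1-yl)amino group or a (3-(dimethylamino)propyl)amino group at this carbonyl carbon would help to separate the two.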